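Removing the ring fluorine from compound 3

The source may report more compounds than this note shows. Statements on the series, on what has been measured and on what is new or still open speak of the compounds shown alone.

Going by these compounds, compound 3 `O=C(O)C[C@H](O)C[C@H](O)CCn1c(-c2ccc(F)cc2)nc(C(=O)NCc2ccccc2F)c1C1CC1` gives "not determined" (no result reported) in a functional assay on cells (Hepatocyte, Rattus norvegicus) for inhibition, read by scintillation counting, with a stated time of 4 h (a higher number here means a weaker inhibitor, a lower number a stronger inhibitor), so it has no result there; its position on the scale is unknown. Two close relatives do have numbers: compound 1 `Cc1ccc(CNC(=O)c2nc(-c3ccc(F)cc3)n(CC[C@@H](O)C[C@@H](O)CC(=O)O)c2C2CC2)cc1` gives 0.1 nM in this assay, and compound 2 `COc1ccc(CNC(=O)c2nc(-c3ccc(F)cc3)n(CC[C@@H](O)C[C@@H](O)CC(=O)O)c2C2CC2)cc1` gives 0.2 nM. Within the data shown here, the only measured step, a 2.0-fold higher number from compound 1 to compound 2 (0.30 log units; within the scatter), concerns a different group on the same ring and stays within the scatter, so no measured step bears directly on the change to compound 4 `O=C(O)C[C@H](O)C[C@H](O)CCn1c(-c2ccc(F)cc2)nc(C(=O)NCc2ccccc2)c1C1CC1`, which is hydrogen in place of fluoro on an aromatic carbon. Given that the two measured relatives sit close together and that a swap on this ring left the number essentially unchanged, compound 4 is expected to land near them, at an estimated 0.2 nM with a range of 0.05 nM to 1 nM.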

Compound 4, half-maximal inhibitory concentration: 0.2 nM
Beside the measured number, compound 4's estimate shows no gap at the digits printed; the range from low to high includes it.
By their numbers in this assay, from the lowest: compounds 1, 2 and 4 (each within the scatter of the next).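

In this assay the benzyl ring of compound 4 carries no substituent, yet there is no change at the digits printed from compound 2 to compound 4 (within the scatter) and a 2.0-fold higher number from compound 1 to compound 4 (0.30 log units; within the scatter) on reaching this bare ring. A methyl or methoxy group on this ring is therefore not needed for a value this low. No measurement at hand explains this. Compound 3 has no number, so the effect of removing the fluoro itself cannot be read. Going by these compounds, whether an amine or a carboxylic acid on this ring would keep the value stays open.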